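Permeability notes on an oxazole–piperidine amide series

The source may hold more compounds than are shown below. What is called first, only, known or untested is meant among the compounds shown, and "the series" means these compounds.

Measured so far:
- compound 1, `Cc1oc(-c2c(F)cccc2F)nc1CN1CCC(C(=O)NCCCN2C[C@H](C)C[C@H](C)C2)CC1`: 82.4 10^-6 cm/s
- compound 2, `CC[C@@H]1C[C@H](CC)CN(CCCNC(=O)C2CCN(Cc3nc(-c4c(F)cccc4F)oc3C)CC2)C1`: 130 10^-6 cm/s

In a physicochemical assay for permeability, using PAMPA (on this read-out lower numbers stand for lower permeability and higher numbers for higher permeability), compound 1 gives 82.4 10^-6 cm/s, and compound 2 gives 130 10^-6 cm/s. Among the compounds with values here, the only measured step, a 1.6-fold higher number from compound 1 to compound 2 (0.20 log units; within the scatter), concerns 3,5-diethylpiperidin-1-yl in place of 3,5-dimethylpiperidin-1-yl, so the two numbers are not separated beyond the scatter and compound 1 cannot be ranked against compound 2.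

Compound 3, `CCc1ccccc1-c1nc(CN2CCC(C(=O)NCCCN3C[C@H](C)C[C@H](C)C3)CC2)c(C)o1`, differs from compound 1 at the other end of the molecule: 2-ethylphenyl in place of 2,6-difluorophenyl on an aromatic carbon. Within the data shown here, no measured step touches this aromatic carbon, and the measured step, a 1.6-fold higher number from compound 1 to compound 2 (0.20 log units; within the scatter), gives no guidance on this change; the group that leaves and the group that enters carry no hydrogen-bond donors or acceptors and no net charge. The expectation is therefore a step of no more than the scatter, a 1.1-fold higher number from compound 1 to compound 3 (0.04 log units; within the scatter). Compound 3 is estimated at 90 10^-6 cm/s in this assay, within 45 10^-6 cm/s to 180 10^-6 cm/s.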

Compound 3, apparent permeability: 106 10^-6 cm/s
For compound 3 the middle estimate is 1.2-fold (0.07 log units) below the measured one, and the stated range covers the measured number.
By their numbers in this assay, from the lowest: compounds 1, 3 and 2 (each within the scatter of the next).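

In this assay, within the data shown here, the aromatic carbon on the ring with one nitrogen and one oxygen is read here for the first time, since the earlier step concerned only the far end of the molecule at the 3,5-dimethylpiperidin-1-yl group. The swap of 2,6-difluorophenyl for 2-ethylphenyl gives a 1.3-fold higher number from compound 1 to compound 3 (0.11 log units; within the scatter) and so stays inside the scatter, even though the two fluorine atoms give way to carbon; the groups match in heavy-atom count, and neither carries hydrogen-bond donors, hydrogen-bond acceptors or a net charge. Nothing available explains this reading or bears on it.

Still open, as far as these compounds go, is how this aromatic carbon reads with a phenyl ring that carries an amine or a carboxylic acid, since both groups compared here lack donors, acceptors and charge. Also open, from the compounds shown here alone, is how 2-ethylphenyl and 3,5-diethylpiperidin-1-yl read together in one compound.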